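The source may report more compounds than this note shows. Statements on the series, on what has been measured and on what is new or still open speak of the compounds shown alone.

Measured so far in a functional assay on NCI-H460 cells (Homo sapiens) for cytotoxicity, read by MTT assay, with a stated time of 72 h; a lower number here means a stronger inhibitor, a higher number a weaker inhibitor:
- compound 1 `CN(C)Cc1ccc2nc(NC(=O)N/N=C/c3cn(Cc4ccccc4)c4ccccc34)sc2c1`: 400 nM
- compound 2 `CN(C)Cc1ccc2nc(NC(=O)N/N=C/c3cn(Cc4ccc(Cl)cc4Cl)c4ccccc34)sc2c1`: 950 nM

Of these two, compound 2 has the higher number, 950 nM, which makes it the weaker inhibitor in this assay. The next compound, compound 3 `CN(C)Cc1ccc2nc(NC(=O)N/N=C/c3cn(Cc4ccc(Cl)c(Cl)c4)c4ccccc34)sc2c1`, has the same atoms as compound 2, joined differently: 3,4-dichlorophenyl in place of 2,4-dichlorophenyl on a saturated chain carbon bound to an aromatic nitrogen. In words, 2,4-dichlorobenzyl gives way to 3,4-dichlorobenzyl, while the shared core stays untouched.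

Within the data shown here, only one measured step bears on this change: a 2.4-fold higher number from compound 1 to compound 2 (0.38 log units; beyond the scatter). It is a modest step, and it came with 2,4-dichlorophenyl in place of phenyl. That step compares a ring with no chlorine to a ring with two, so it is only an indirect guide. Among the measured compounds shown here, no measured pair shows what happens when the two dichlorophenyl groups are exchanged, so the data give no direction for this change. The expected result is therefore a 1.2-fold lower number from compound 2 to compound 3 (0.07 log units; within the scatter), with no shift beyond the scatter anticipated. For compound 3 the estimated value is 800 nM, with an expected range from 300 nM to 2000 nM.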

Compound 3, half-maximal inhibitory concentration: 1360 nM
Compound 3: the middle estimate sits 1.7-fold (0.23 log units) below what was measured; measured number inside the range.
By their numbers in this assay, from the lowest: compound 1; then compounds 2 and 3 (each within the scatter of the next).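

In this assay, shifting the chlorines from 2,4-dichlorobenzyl to 3,4-dichlorobenzyl gives a 1.4-fold higher number from compound 2 to compound 3 (0.16 log units; within the scatter) and stays within the usual scatter, so the arrangement of the two chlorines on this ring makes no difference that can be read here. Placing the new ring against the plain benzyl group of compound 1 gives a 3.4-fold higher number from compound 1 to compound 3 (0.53 log units; beyond the scatter) and lies beyond the scatter, so two differently chlorinated rings, rather than one, now carry higher numbers than the unsubstituted phenyl at this position, and neither of them goes against that picture. No supporting measurement explains how the chlorines produce this shift.

Both chlorinated compounds carry two chlorines, so the compounds shown cannot say whether a single chlorine on the phenyl ring would be enough to raise the number, or whether each chlorine contributes separately. They also leave open how this position would respond to a group other than chlorine on the ring, such as methoxy or an amine, or to a longer chain carrying the ring on the aromatic nitrogen.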